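Moving the imidazole around the amide ring

The compounds below may be only part of what the source reports. "The series", "measured", "known", "first", "only" and "open" are said of these compounds alone.

Measured compounds, with their numbers in an assay on brain for displacement of a labelled ligand from D(3) dopamine receptor (Rattus norvegicus); a lower number here means a stronger inhibitor, a higher number a weaker inhibitor:
compound 1 `CCCN(CC[C@H]1CC[C@H](NC(=O)/C=C/c2ccccc2Cl)CC1)[C@H]1CCc2nc(N)sc2C1` gives 1.2 nM
compound 2 `CCCN(CC[C@H]1CC[C@H](NC(=O)c2cccc3ncccc23)CC1)[C@H]1CCc2nc(N)sc2C1` gives 1.6 nM
compound 3 `CCCN(CC[C@H]1CC[C@H](NC(=O)c2ccc(-n3ccnc3)cc2)CC1)[C@H]1CCc2nc(N)sc2C1` gives 1.9 nM

All three share one core and differ only in the group on the carbonyl carbon. Their numbers stay within the scatter of one another: a 1.3-fold higher number from compound 1 to compound 2 (0.12 log units; within the scatter), a 1.6-fold higher number from compound 1 to compound 3 (0.20 log units; within the scatter) and a 1.2-fold higher number from compound 2 to compound 3 (0.07 log units; within the scatter). Compound 3 therefore cannot be set apart from compound 1 or compound 2 in this assay.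

Compound 4 `CCCN(CC[C@H]1CC[C@H](NC(=O)c2cccc(-n3ccnc3)c2)CC1)[C@H]1CCc2nc(N)sc2C1` differs from compound 3 by 3-(1H-imidazol-1-yl)phenyl in place of 4-(1H-imidazol-1-yl)phenyl on a carbonyl carbon; the two have the same atoms, joined differently. The measured steps each exchanged the whole group on the carbonyl carbon for a group of quite different shape and still gave changes within the scatter, which suggests this part of the molecule tolerates variation. None of those steps moved a substituent within an otherwise unchanged group, so they bear on the present step only indirectly. A step within the scatter is therefore expected, a 1.3-fold higher number from compound 3 to compound 4 (0.12 log units; within the scatter). Compound 4 is estimated at 2.5 nM, with a range from 0.9 nM to 7 nM.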

Compound 4, inhibition constant: 1.1 nM
The estimate for compound 4 lay 2.3-fold (0.36 log units) above the measured number; the range from low to high includes it.
By their numbers in this assay, from the lowest: compounds 4, 1, 2 and 3 (each within the scatter of the next).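

Swapping 4-(1H-imidazol-1-yl)phenyl for 3-(1H-imidazol-1-yl)phenyl keeps the atoms and ring types the same, so this is the first step here that moves a group within an otherwise unchanged substituent, and in this assay it stays within the scatter (a 1.7-fold lower number from compound 3 to compound 4 (0.24 log units; within the scatter)). Compound 4 also cannot be set apart from the two compounds with different groups on the carbonyl carbon (a 1.5-fold lower number from compound 2 to compound 4 (0.16 log units; within the scatter); a 1.1-fold lower number from compound 1 to compound 4 (0.04 log units; within the scatter)), so among these four compounds, relocating the imidazole is tolerated just as exchanging the whole group was. Nothing shown explains why this position accepts these changes so evenly.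

Going by these compounds, whether a carboxylic acid or a simple amine in place of the imidazole would also stay within the scatter remains open. So does the effect of a longer chain on the carbonyl carbon.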